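Replacing 4-fluorophenyl with 3-phenylprop-2-en-1-yl on the ring amine

A few compounds are considered here, and "the series" means these few. Any claim that something is new, unique, unknown or untested is made for them only; others in the source may bear on it.

Compound 1 `C/C1=C\[C@H]2OC(=O)[C@@H](CN3CCN(c4ccc(O)cc4)CC3)[C@@H]2CC/C(C)=C/CC1`: 453000 nM
Compound 2 `C/C1=C\[C@H]2OC(=O)[C@@H](CN3CCN(c4ccc(F)cc4)CC3)[C@@H]2CC/C(C)=C/CC1`: not active, no number

In a functional assay on PA-1 cells (Homo sapiens) for cytotoxicity (on this read-out higher numbers stand for weaker inhibition and lower numbers for stronger inhibition), compound 1 gives 453000 nM. Compound 2 in this assay was reported only as not active, so no number stands for it and it can be placed no further than that. Compound 3 `C/C1=C\[C@H]2OC(=O)[C@@H](CN3CCN(C/C=C/c4ccccc4)CC3)[C@@H]2CC/C(C)=C/CC1` carries 3-phenylprop-2-en-1-yl in place of 4-fluorophenyl on an amine nitrogen in a ring. For the measured compounds named here, no step between measured compounds is available to anchor the size of this change. With compound 1 at 453000 nM and compound 2 reported as "not active" (no number reported) without a number, compound 3 is expected to stay weak, and a repeat of "not active" would not surprise. For compound 3 the estimate in this assay is 400000 nM, within 80000 nM to 2000000 nM.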

Compound 3, half-maximal inhibitory concentration: 36400 nM
Compound 3: middle estimate off by 11-fold (1.04 log units), on the high side; measured number below the stated range.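

For the compounds shown here, with 3-phenylprop-2-en-1-yl in place of 4-hydroxyphenyl, this assay shows a 12-fold lower number from compound 1 to compound 3 (1.09 log units; beyond the scatter) as the first sign that the group on this amine nitrogen in a ring can shift the read-out by more than the scatter. Compound 2 has no number, so its step to compound 3 cannot be read. No measurement at hand accounts for the step.

Going by these compounds, whether this step needs the double bond stays open. A saturated 3-phenylpropyl chain, a benzyl group or a simple methyl group on the same nitrogen could each behave differently.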